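The compounds below may be only part of what the source reports. "The series", "measured", "known", "first", "only" and "open" are said of these compounds alone.

Series notes. Going by the values given here, compound 1 `Cc1cccc(NC(=O)CN2CCC(c3nccs3)CC2)c1` gives 1 nM in a functional assay on HEK293 cells for agonist activity at D(4) dopamine receptor (Homo sapiens), read by FLIPR (on this read-out lower numbers stand for an effect already at smaller amounts and higher numbers for an effect only at larger amounts of compound), and stands lowest of the three numbers measured so far. Compound 2 `Cc1cc(NC(=O)CN2CCC(c3cccc[n+]3[O-])CC2)ccc1F` gives 18 nM in this assay, and compound 3 `O=C(CN1CCC(c2cccc[n+]2[O-])CC1)Nc1cccc(Cl)c1` gives 62 nM. Among the compounds with values here, the one measured step, a 3.4-fold higher number from compound 2 to compound 3 (0.54 log units; beyond the scatter), concerns the group on the amide-type nitrogen and leaves the saturated ring carbon untouched. Compound 4 `Cc1cccc(NC(=O)CN2CCC(c3ccccc3F)CC2)c1` differs from compound 1 by 2-fluorophenyl in place of 1,3-thiazol-2-yl on a saturated ring carbon. Within the data shown here, no measured step bears on this change; compound 2 and compound 3 differ from compound 1 at the amide-type nitrogen as well, so their higher numbers cannot be attributed to the saturated ring carbon alone. The expected step is a 5.0-fold higher number from compound 1 to compound 4 (0.70 log units; beyond the scatter) in this assay, with wide uncertainty in both directions. Compound 4 is estimated at 5 nM, within 1 nM to 30 nM.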

Compound 4, half-maximal effective concentration: 1 nM
The estimate for compound 4 lay 5.0-fold (0.70 log units) above the measured number; low and high end bracket the measured number.
By their numbers in this assay, from the lowest: compounds 1 and 4 (each within the scatter of the next); then compound 2; then compound 3.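

On the saturated ring carbon, 2-fluorophenyl in place of 1,3-thiazol-2-yl gives no change at the digits printed from compound 1 to compound 4 (within the scatter) in this assay. In this pair, a six-membered aromatic ring of carbon only thus stands in for a five-membered aromatic ring with 2 hetero atoms, and the 2 hydrogen-bond acceptors counted on the leaving group go without a readable shift. No available evidence accounts for this result. Still open, from the compounds shown here alone, is whether a non-aromatic group at this carbon, such as an amine or a carboxylic acid, would keep the number there. Also open, going by these compounds, is whether the same exchange behaves alike with 3-chlorophenyl on the amide-type nitrogen.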